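Acetamido gives way to 1H-pyrrol-1-yl in a cytotoxicity test

This account rests on a few compounds, and the source may have more. Where it says the series, first, only, none or still open, it means among the compounds named here.

Values so far in an ADME assay on HeLa cells (Homo sapiens) for cytotoxicity, read by crystal violet staining, with a stated time of 72 h (on this read-out lower numbers stand for higher toxicity in this test and higher numbers for lower toxicity in this test), are these.
Compound 1 `CCOC(=O)c1cc(CCCOc2ccc(-c3noc(C(F)(F)F)n3)cc2)on1` gives > 100000 nM as a limit
Compound 2 `CCOC(=O)c1cc(CCCOc2ccc(-c3noc(C(F)(F)F)n3)cc2NC(C)=O)on1` gives > 100000 nM as a limit

Compound 2 gives > 100000 nM in this assay, which is a limit and not a number. Among the measured compounds shown here, the same holds for the only other value, as the limit of > 100000 nM in this assay, at which 2 of the 2 values shown sit, shows. Compound 3 `CCOC(=O)c1cc(CCCOc2ccc(-c3noc(C(F)(F)F)n3)cc2-n2cccc2)on1` carries 1H-pyrrol-1-yl in place of the acetamido of compound 2, on an aromatic carbon, ortho to a large group and meta to a 5-(trifluoromethyl)-1,2,4-oxadiazol-3-yl group (1H-pyrrol-1-yl in place of acetamido on an aromatic carbon). For the measured compounds named here, the one measured step that bears on this change is a step that the two limits leave unreadable from compound 1 to compound 2, so it offers no size to carry over. No step beyond the scatter is therefore expected in this assay, and the expected step is a number no higher from compound 2 to compound 3 (the limit leaves the size open). For compound 3 the estimate is 100000 nM, with an expected range from 50000 nM to 200000 nM, and the assay will most likely report only a limit again.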

Compound 3, half-maximal cytotoxic concentration: 57300 nM
Compound 3: the middle estimate sits 1.7-fold (0.24 log units) above what was measured, and the stated range covers the measured number.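

In this assay compound 3 gives 57300 nM. This makes compound 3 the first of the three to give a number and not a limit, so 1H-pyrrol-1-yl on this aromatic carbon, ortho to a large group, yields a readable value where hydrogen and acetamido gave only limits. The change reads as an at least 1.7-fold lower number from compound 2 to compound 3 (0.24 log units; that floor lies within the scatter) and as an at least 1.7-fold lower number from compound 1 to compound 3 (0.24 log units; that floor lies within the scatter), so each step is known only as a floor and not as a full size. The step between compound 1 and compound 2 still cannot be read, as both remain limits: the limit of > 100000 nM in this assay, at which 2 of the 3 values shown sit.

On these data alone, it remains open whether an amine or a phenyl ring on the same aromatic carbon would also give a number. Also open, as far as these compounds go, is how a carboxylic acid in place of the ethyl ester would read alongside 1H-pyrrol-1-yl.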